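Ester chain length on the shared core: compound 4

The source may report more compounds than this note shows. Statements on the series, on what has been measured and on what is new or still open speak of the compounds shown alone.

Compound 1 `CCOC(=O)COc1ccc2c(=O)c(-c3ccc(O)cc3)coc2c1`: 130 nM
Compound 2 `CCOC(=O)CCCCOc1ccc2c(=O)c(-c3ccc(O)cc3)coc2c1`: 240 nM
Compound 3 `O=C(O)CCCCCCCCCOc1ccc2c(=O)c(-c3ccc(O)cc3)coc2c1`: 50 nM

In an assay (Cricetulus griseus) for inhibition of aldehyde dehydrogenase, mitochondrial (Homo sapiens) (on this read-out higher numbers stand for weaker inhibition and lower numbers for stronger inhibition), compound 1 gives 130 nM, the second highest of the three numbers shown; compound 3 gives the lowest number, 50 nM. Compound 4 `CCOC(=O)CCCCCOc1ccc2c(=O)c(-c3ccc(O)cc3)coc2c1` differs from compound 1 by 4-(ethoxycarbonyl)butyl in place of ethoxycarbonyl on a saturated chain carbon bound to an oxygen on an aromatic ring. The nearest measured step is a 1.8-fold higher number from compound 1 to compound 2 (0.27 log units; within the scatter), the same kind of ester chain lengthening, and it stayed within the scatter. The further step a 4.8-fold lower number from compound 2 to compound 3 (0.68 log units; beyond the scatter) did lower the number, but it brought in a longer chain and a carboxylic acid as well, so it bears only loosely here. For compound 4 no step beyond the scatter is expected, a 1.2-fold higher number from compound 1 to compound 4 (0.06 log units; within the scatter). Compound 4 is therefore estimated at 150 nM, with a range from 60 nM to 380 nM.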

Compound 4, half-maximal inhibitory concentration: 280 nM
The estimate for compound 4 lay 1.9-fold (0.27 log units) below the measured number; the range from low to high includes it.
By their numbers in this assay, from the lowest: compound 3; then compounds 1, 2 and 4 (each within the scatter of the next, the first and the last beyond it).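

In this assay, within the data shown here, the change to 4-(ethoxycarbonyl)butyl gives a 2.2-fold higher number from compound 1 to compound 4 (0.33 log units; beyond the scatter) and is the first ester lengthening at this position to pass the scatter, while the two longer esters stay together with a 1.2-fold higher number from compound 2 to compound 4 (0.07 log units; within the scatter) as their step. The acid remains apart from this ester with a 5.6-fold higher number from compound 3 to compound 4 (0.75 log units; beyond the scatter) as its step, although that step changes more than the end group alone. No supporting data explain these differences. Open, on these data alone, is whether a carboxylic acid on the shorter chains would match the number of compound 3 or whether the ester or the chain length sets it. As far as these compounds go, an amine or an amide at the chain end also remains untested.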